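The compounds below may be only part of what the source reports. "The series", "measured", "known", "first", "only" and "open" are said of these compounds alone.

Measured so far:
compound 1 `Cc1nc2c(CSc3ccccc3)cccn2c1C` — 29%
compound 2 `Cc1nc2c(OCc3ccccc3)cccn2c1CO` — 99%

In a functional assay on the whole organism with Rattus norvegicus as the target, with a stated time of 4 h, at a dose of 40 mg/kg by the intraperitoneal route (on this read-out higher numbers stand for more inhibition at the one dose given (going by the name of the read-out) and lower numbers for less inhibition), compound 2 gives 99%, the higher of the two numbers recorded, and its nearest neighbour is compound 1, well beyond the scatter below it. In this assay, for the measured compounds named here, compound 1 gives 29%; the two compounds differ in more than one place and no single step between them has been worked out, so the gap says nothing about either change on its own.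

Compound 3 `COC(=O)Cc1c(C)nc2c(OCc3ccccc3)cccn12` has not yet been measured in this assay. It differs from compound 2 in one place: methoxycarbonyl in place of hydroxy on a saturated chain carbon bound to an aromatic carbon.

Going by the values given here, no measured step of this kind exists. A downward step of moderate size is expected for a number 27 percentage points lower from compound 2 to compound 3 (beyond the scatter), because compound 2 gives 99%, close to the top of the scale, so any move beyond the scatter can only run downward. Compound 3 is therefore estimated at 72%, within 35% to 98%.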

Compound 3, a percentage reported as inhibition, in the whole organism at one dose (the size of the read-out at that dose, not a potency): 23%
Estimate against measurement, compound 3: 49 percentage points above; the measured number lies below the stated range.
By their numbers in this assay, from the lowest: compounds 3 and 1 (each within the scatter of the next); then compound 2.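

In this assay, for the compounds shown here, the replacement of hydroxy by methoxycarbonyl on a saturated chain carbon bound to an aromatic carbon gives a number 76 percentage points lower from compound 2 to compound 3 (beyond the scatter), the first single-place step, large and beyond the scatter. This position is therefore not indifferent to its substituent: with the rest of the structure unchanged, hydroxymethyl and (methoxycarbonyl)methyl give clearly different read-outs at the one dose. Nothing in the data on hand accounts for the step.

The step changes the end group and the chain together, so it leaves open whether the drop follows the ester or the longer chain. A carboxylic acid or a 2-hydroxyethyl group in the same place would separate these two readings, and neither is among the compounds shown.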